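This account rests on a few compounds, and the source may have more. Where it says the series, first, only, none or still open, it means among the compounds named here.

Notes on a small series built on one shared core. In a functional assay on Huh-7 cells (Homo sapiens) for inhibition, read by sulforhodamine B assay, with a stated time of 72 h (on this read-out higher numbers stand for weaker inhibition and lower numbers for stronger inhibition), compound 1 `COc1ccc(C(=O)/C=C/c2cn(-c3ccccc3)nc2-c2ccsc2)c(OC)c1OC` gives 4200 nM. In this assay compound 2 `O=C(/C=C/c1cn(-c2ccccc2)nc1-c1cccnc1)c1ccsc1` gives 1700 nM, the second highest of the three numbers recorded so far; compound 1 stands nearest to it, with a gap that is already beyond the usual scatter, and compound 3 stands furthest from it. In this assay compound 3 `COc1cc(OC)c(C(=O)/C=C/c2cn(-c3ccccc3)nc2-c2cccnc2)c(OC)c1` gives 500 nM, the lowest of the three. Compound 4 `COc1ccc(C(=O)/C=C/c2cn(-c3ccccc3)nc2-c2cccnc2)cc1OC` has not yet been run in this assay. It differs from compound 2 in one place: 3,4-dimethoxyphenyl in place of thiophen-3-yl on a carbonyl carbon. Within the data shown here, no pair of measured compounds covers exactly this change. Compound 2 at 1700 nM and compound 3 at 500 nM differ only in the group on the carbonyl carbon, and there the methoxy-bearing group of compound 3 sits at the lower number. On that basis a step toward stronger inhibition is expected for compound 4, of moderate size and probably beyond the scatter, as a 1.7-fold lower number from compound 2 to compound 4 (0.23 log units; within the scatter). Compound 1 at 4200 nM also carries methoxy groups on the ring at the carbonyl carbon yet stands highest, which cautions against expecting a large move. In this assay compound 4 is estimated at 1000 nM, within a range from 300 nM to 3500 nM.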

Compound 4, half-maximal inhibitory concentration: 3100 nM
Compound 4: the middle estimate sits 3.1-fold (0.49 log units) below what was measured; the measured number falls inside the stated range.
By their numbers in this assay, from the lowest: compound 3; then compounds 2, 4 and 1 (each within the scatter of the next, the first and the last beyond it).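

At the group on a carbonyl carbon, thiophen-3-yl gives way to the larger 3,4-dimethoxyphenyl in this assay with a 1.8-fold higher number from compound 2 to compound 4 (0.26 log units; within the scatter), so this position accepts an aromatic group of more heavy atoms, and one with an added hydrogen-bond acceptor, with no change that can be told from the scatter. Methoxy groups on the ring at this position therefore do not by themselves go with a low number: compound 4 at 3100 nM differs only in this group from compound 3 at 500 nM, and compound 3 is the one compound of the pair that goes against any such reading of compound 2 and compound 4 as a flat position. Nothing on hand accounts for the difference between the two methoxy-bearing groups.

Open, from the compounds shown here alone, is whether the number of methoxy groups or their placement on the ring decides the outcome, as the two rings here differ in both at once. Also open, going by these compounds, is how this position responds to a group without an aromatic ring, such as an amine, a carboxylic acid or a longer chain, on the carbonyl carbon.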